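Working notes: methyl on the aromatic oxygen of compound 2

A few compounds are considered here, and "the series" means these few. Any claim that something is new, unique, unknown or untested is made for them only; others in the source may bear on it.

Measured so far:
compound 1 `C/C(=N\OCC(=O)O)c1ccccc1` — < 20%
compound 2 `C/C(=N\OCC(=O)O)c1ccc(O)cc1` — < 20%

Both values come from a functional assay on the whole organism for inhibition, with Rattus norvegicus as the target, read by paw edema, with stated times of 1 h and 3 h, at a dose of 50 mg/kg by the oral route; on this read-out higher numbers stand for more inhibition at the one dose given (going by the name of the read-out) and lower numbers for less inhibition. In this assay compound 1 gives < 20%, which is a limit of the assay and not a number. In this assay compound 2 likewise gives < 20%, again a limit rather than a number. Among the compounds with values here, the single measured step, a step that the two limits leave unreadable from compound 1 to compound 2, therefore cannot be read, and the only evidence on the series is the limit of < 20% in this assay, at which 2 of the 2 values shown sit.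

The next compound is compound 3 `COc1ccc(/C(C)=N/OCC(=O)O)cc1`. It differs from compound 2 in one place: methyl in place of hydrogen on an oxygen on an aromatic ring. Within the data shown here, no measured step bears on this change, since the one step available is unreadable and both measured compounds sit at the limit. The expectation is accordingly that compound 3 also stays at that limit in this assay, with the step that the limit leaves unreadable from compound 2 to compound 3 expected to be none beyond the scatter. The estimate for compound 3 in this assay is 12%, with a range from 0% to 28%.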

Compound 3, a percentage reported as inhibition, in the whole organism at one dose (the size of the read-out at that dose, not a potency): < 20%
Compound 3 ended at the assay's limit (the forecaster's own chance of this, stated with the estimate: 70%); the middle value lies beyond the limit too.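

No step among compound 1, compound 2 and compound 3 can be read in this assay, and the series rests on a single observation: the limit of < 20% in this assay, at which 3 of the 3 values shown sit.

The compounds shown leave open whether any change on the aromatic ring gives inhibition clear of that limit, and how large the steps to hydroxy and methoxy from hydrogen really are.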